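From ethyl to 4-chlorophenyl on a well-tolerated core

The source may report more compounds than this note shows. Statements on the series, on what has been measured and on what is new or still open speak of the compounds shown alone.

Values in a functional assay on Huh-7 cells (Homo sapiens) for cytotoxicity, read by MTT assay, with a stated time of 72 h; a lower number here means that less compound is tolerated, a higher number that more compound is tolerated (each one a limit of the assay and not a number):
- compound 1 `CCCS(=O)(=O)N1CCC2(CC1)OOC1(CCCC1)OO2` gives > 100 ug/mL
- compound 2 `CCCCS(=O)(=O)N1CCC2(CC1)OOC1(CCCCCC1)OO2` gives > 100 ug/mL
- compound 3 `CCCS(=O)(=O)N1CCC2(CC1)OOC(C)(CC)OO2` gives > 100 ug/mL

In this assay compound 3 stands at > 100 ug/mL as a limit of the assay and not a number. Compound 1 and compound 2 stand in the same place, so the three cannot be ranked. All that can be said so far is this: the limit of > 100 ug/mL in this assay, at which 3 of the 3 values shown sit, and nothing more.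

The next compound is compound 4 `CCCS(=O)(=O)N1CCC2(CC1)OOC(C)(c1ccc(Cl)cc1)OO2`, which keeps everything else of compound 3. The change 4-chlorophenyl in place of ethyl on a saturated ring carbon puts 4-chlorophenyl in place of ethyl on a saturated ring carbon. It brings a six-membered aromatic ring of carbon only, which none of the three measured compounds carries.

For the measured compounds named here, no two measured compounds differ in one place only, so the data offer no size for a single change to go by. The expected step of an at least 1.1-fold lower number from compound 3 to compound 4 (0.07 log units; that floor lies within the scatter) is a small one toward lower numbers, and the assay may well report a limit again. The estimate for compound 4 is 85 ug/mL with an expected range of 35 ug/mL to 150 ug/mL as the likely span.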

Compound 4, half-maximal cytotoxic concentration: > 100 ug/mL
Compound 4 gave a limit, no number; the forecaster's own chance of this, stated with the estimate: 55%; at least 1.1-fold (0.07 log units) between middle value and limit.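

In this assay compound 4 gives > 100 ug/mL, a limit of the assay and not a number. For the compounds shown here, compound 3 sits at the same limit, so no step between compound 3 and compound 4 can be read. The compounds shown leave open at what concentration any of them would begin to harm these cells: the limit of > 100 ug/mL in this assay, at which 4 of the 4 values shown sit.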